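The source may hold more compounds than are shown below. What is called first, only, known or untested is meant among the compounds shown, and "the series" means these compounds.

Measured so far in a functional assay on ME-180 cells (Homo sapiens) for cytotoxicity, read by MTT assay, with a stated time of 72 h; on this read-out lower numbers stand for stronger inhibition and higher numbers for weaker inhibition:

compound 1, `COc1cccc(/C=C/C(=O)Nc2cc(C(=O)c3cc(OC)c(OC)c(OC)c3)ccc2OC)c1`, 4300 nM
compound 2, `COc1ccc(C(=O)c2cc(OC)c(OC)c(OC)c2)cc1NC(=O)/C=C/c1cccc(OC(F)(F)F)c1`, 9200 nM
compound 3, `COc1ccc(/C=C/C(=O)Nc2cc(C(=O)c3cc(OC)c(OC)c(OC)c3)cc(OC)c2OC)cc1OC`, 6700 nM

Compound 3 gives 6700 nM in this assay, and that number lies within the scatter of both neighbours: compound 1 with 4300 nM and compound 2 with 9200 nM. For the measured compounds named here, on these three numbers no compound is separated from the others by more than the scatter, except along the one counted step, from compound 1 to compound 2, which reads a 2.1-fold higher number from compound 1 to compound 2 (0.33 log units; beyond the scatter) for trifluoromethyl in place of methyl on an oxygen on an aromatic ring.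

Compound 4, `COc1cccc(/C=C/C(=O)Nc2cc(C(=O)c3cc(OC)c(OC)c(OC)c3)cc(OC)c2OC)c1`, follows from compound 3 by hydrogen in place of methoxy on an aromatic carbon of a six-membered aromatic ring of carbon only, ortho to a methoxy group and para to a large group. Going by the values given here, no measured step concerns this change; the only one in hand is the trifluoromethyl step, which touches another group altogether. Compound 1 and compound 3 differ in two places, one of them this methoxy, and their numbers sit within the scatter of each other. The step from compound 3 to compound 4 in this assay is therefore expected to be a 1.2-fold lower number from compound 3 to compound 4 (0.09 log units; within the scatter), nothing beyond the scatter. Compound 4 is estimated at 5500 nM, within a range from 2500 nM to 12000 nM.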

Compound 4, half-maximal inhibitory concentration: 8600 nM
Compound 4: the middle estimate sits 1.6-fold (0.19 log units) below what was measured, within the range that was stated.
By their numbers in this assay, from the lowest: compounds 1, 3, 4 and 2 (each within the scatter of the next, the first and the last beyond it).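

For the compounds shown here, with the methoxy of the 3,4-dimethoxyphenyl group as the only change, going to the 3-methoxyphenyl group in this assay moves the number by no more than the scatter (a 1.3-fold higher number from compound 3 to compound 4 (0.11 log units; within the scatter)), so this position, ortho to a methoxy group and para to a large group, now has a reading of its own, where compound 1 and compound 3 differed in two places at once. Compound 4 also isolates the second of those two places: methoxy in place of hydrogen on an aromatic carbon of the core likewise stays within the scatter (a 2.0-fold higher number from compound 1 to compound 4 (0.30 log units; within the scatter)), so neither change taken alone separates its pair in this assay, unlike the trifluoromethyl step. Nothing at hand gives a reason for these small steps.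

The two groups read at this position, methoxy and hydrogen, say nothing about how a hydroxyl, an amine or a longer ethoxy chain would read there. Going by these compounds, it also stays open whether the methoxy that remains on the ring, in the 3-methoxyphenyl group of compound 4, can be taken away or replaced with as little consequence in this read-out.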